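This account rests on a few compounds, and the source may have more. Where it says the series, first, only, none or still open, it means among the compounds named here.

Compound 1 `Cn1c(=O)c(S(=O)(=O)c2ccc(O)cc2)cc2cnc(Nc3ccc4[nH]ccc4c3)nc21` is the reference point of this set. Within the data shown here, in a functional assay on DU-145 cells (Homo sapiens) for inhibition, read by trypan blue exclusion, with a stated time of 72 h (a lower number here means a stronger inhibitor, a higher number a weaker inhibitor), compound 1 gives 250 nM, the lowest of the three numbers measured so far, and both of its companions lie beyond the scatter of repeated measurements. Compound 3 `O=c1c(S(=O)(=O)c2ccc(F)cc2F)cc2cnc(Nc3ccc4[nH]ccc4c3)nc2n1C1CCCCC1`, which carries a difluorinated sulfonyl aryl group and a cyclohexyl substituent on the core, gives 10000 nM. Compound 2 `COc1ccc(Nc2ncc3cc(S(=O)(=O)c4ccc(C)cc4)c(=O)n(C)c3n2)cc1`, with a methoxy-substituted anilino group and a methyl on the sulfonyl aryl ring, gives 100000 nM, the highest value recorded. Each of these compounds differs from compound 1 in more than one place. Among the measured compounds shown here, the numbers show only that compound 1 stands well ahead of both; no single change can be credited for the gaps.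

The step considered next leads to compound 4 `Cn1c(=O)c(S(=O)(=O)c2ccc(F)cc2)cc2cnc(Nc3ccc4[nH]ccc4c3)nc21`. The change is fluoro in place of hydroxy on an aromatic carbon. For the measured compounds named here, no measured pair isolates this exchange, so the expectation rests on the structural change alone. A modest weakening is expected, with the step from compound 1 to compound 4 estimated as a 2.4-fold higher number from compound 1 to compound 4 (0.38 log units; beyond the scatter), a size that may not clear the scatter. Compound 4 is accordingly expected to give about 600 nM, with a likely range from 150 nM to 3000 nM.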

Compound 4, half-maximal inhibitory concentration: 300 nM
Compound 4: the middle estimate sits 2.0-fold (0.30 log units) above what was measured, and the stated range covers the measured number.
By their numbers in this assay, from the lowest: compounds 1 and 4 (each within the scatter of the next); then compound 3; then compound 2.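

In this assay, among these compounds, the pair formed by compound 1 and compound 4 is the first in this set to differ in one place, which the earlier compounds could not offer, and it gives a 1.2-fold higher number from compound 1 to compound 4 (0.08 log units; within the scatter). At this position, para to a large group on the sulfonyl aryl ring, 4-hydroxyphenyl can therefore give way to 4-fluorophenyl, with the hydrogen-bond donor and acceptor counted on the hydroxy leaving with it, and the two numbers still stand within the scatter of each other. Nothing measured alongside these compounds bears on why the exchange has so small a step, so the result remains a plain observation for this one pair.

On these data alone, whether a larger or differently built group at the same position, such as an amine, a nitrile or a carboxylic acid, would also stay within the scatter remains open, as does whether the exchange would read the same on a core carrying cyclohexyl rather than methyl. The far higher numbers of compound 2 and compound 3 also remain unassigned, since no single change links either of them to compound 1 or compound 4.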